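Swapping the amine link for an ether in the aryl substituent

A few compounds are considered here, and "the series" means these few. Any claim that something is new, unique, unknown or untested is made for them only; others in the source may bear on it.

Measured so far:
Compound 1 `N#Cc1ccc(CNc2ccc(-c3c(N)nc(N)nc3COCc3ccccc3)cc2)cc1` — 2.8 nM
Compound 2 `CC(C)(C)CNc1ccc(-c2c(N)nc(N)nc2COCc2ccccc2)cc1` — 67 nM

Both compounds were tested in an in vitro assay on CHOK cells for displacement of a labelled ligand from growth hormone secretagogue receptor type 1 (Homo sapiens); a lower number here means a stronger inhibitor, a higher number a weaker inhibitor. Among the two numbers, compound 2 has the highest one, so it is the weaker binder; its nearest neighbour is compound 1, and the step of a 24-fold higher number from compound 1 to compound 2 (1.38 log units; beyond the scatter) is large. That step swaps tert-butyl in place of 4-cyanophenyl on a saturated chain carbon bound to a nitrogen on an aromatic ring.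

Compound 3 `N#Cc1ccc(COc2ccc(-c3c(N)nc(N)nc3COCc3ccccc3)cc2)cc1` is not yet measured. It differs from compound 2 by (4-cyanobenzyl)oxy in place of neopentylamino on an aromatic carbon. In effect compound 3 brings back the 4-cyanobenzyl group of compound 1 but joins it to the aromatic ring through an oxygen instead of a nitrogen. Going by the values given here, the only step available, from compound 1 to compound 2, shows how much the 4-cyanophenyl piece is worth, and compound 3 recovers it. Among the compounds with values here, no measured pair tells what replacing the nitrogen link by oxygen does. The expectation for compound 3 is therefore a return toward the low number of compound 1, that is, a step of a 13-fold lower number from compound 2 to compound 3 (1.13 log units; beyond the scatter) in this assay. The estimated value for compound 3 is 5 nM, with a range from 1.5 nM to 20 nM.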

Compound 3, half-maximal inhibitory concentration: 83 nM
Estimate against measurement, compound 3: 17-fold (1.22 log units) below; the whole stated range lies below it.
By their numbers in this assay, from the lowest: compound 1; then compounds 2 and 3 (each within the scatter of the next).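

In this assay, exchanging the nitrogen link for an oxygen while keeping the 4-cyanobenzyl group gives a 30-fold higher number from compound 1 to compound 3 (1.47 log units; beyond the scatter) and so loses most of what compound 1 offers, which shows that the linking atom at this aromatic carbon counts heavily. The 4-cyanobenzyl group therefore does not bring a low number on its own: with the oxygen link it ends up level with the neopentylamino group, as a 1.2-fold higher number from compound 2 to compound 3 (0.09 log units; within the scatter) shows, even though the two groups share little beyond their attachment to the same ring carbon. Among these three compounds, only the combination of 4-cyanobenzyl and the amino link gives the low number, and nothing presented here explains why the oxygen link behaves so differently.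

From the compounds shown here alone, it remains open whether a neopentyloxy group, which would pair the oxygen link with the smaller chain, would stay level with compound 2 and compound 3 or fall away further. Also open, going by these compounds, is whether a methylene link or a methylamino link carrying the same 4-cyanobenzyl group would behave like the amino link of compound 1 or the ether link of compound 3.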